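A few compounds are considered here, and "the series" means these few. Any claim that something is new, unique, unknown or untested is made for them only; others in the source may bear on it.

Compound 3 `O=C(Nc1cccc(-n2cc(-c3ccncc3)c(-c3cc(O)cc(Cl)c3)n2)c1)c1cc(C(F)(F)F)cc(C(F)(F)F)c1` holds the highest of the three numbers in a functional assay on UACC-257 cells (Homo sapiens) for inhibition, read by sulforhodamine B assay, with a stated time of 48 h, tested at 10 uM (on this read-out lower numbers stand for a stronger effect and higher numbers for a weaker effect at the one concentration tested), where compound 3 gives 71%. Compound 2 `COc1cc(Cl)cc(-c2nn(-c3cccc(NC(=O)c4cccc(C(F)(F)F)c4)c3)cc2-c2ccncc2)c1` lies nearest: in this assay compound 2 gives 68.7%, within the scatter of compound 3. Compound 1 `COc1cc(Cl)cc(-c2nn(-c3cccc(NC(=O)Nc4ccc(Cl)c(Cl)c4)c3)cc2-c2ccncc2)c1` lies furthest: in this assay compound 1 gives -11.5%. Within the data shown here, the only measured step, a number 80.2 percentage points higher from compound 1 to compound 2 (beyond the scatter), concerns the group on the carbonyl carbon and not the change now at hand. Compound 4 `COc1cc(Cl)cc(-c2nn(-c3cccc(NC(=O)c4cc(C(F)(F)F)cc(C(F)(F)F)c4)c3)cc2-c2ccncc2)c1` differs from compound 3 by methyl in place of hydrogen on an oxygen on an aromatic ring. Compounds 2 and 3 differ in two places, so their values bear on this change only loosely, yet they sit close together. Compound 4 is therefore expected to show a number 1 percentage points lower from compound 3 to compound 4 (within the scatter), no step beyond the scatter. The estimate for compound 4 is 70%, between 50% and 90%.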

Compound 4, a percentage reported as activity, at one concentration (the size of the read-out at that concentration, not a potency): 79.3%
Compound 4: middle estimate off by 9.3 percentage points, on the low side; the range from low to high includes it.
By their numbers in this assay, from the lowest: compound 1; then compounds 2, 3 and 4 (each within the scatter of the next, the first and the last beyond it).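

In this assay, among these compounds, hydroxy to methoxy on the aromatic ring gives a number 8.3 percentage points higher from compound 3 to compound 4 (within the scatter), the first direct reading of this change, and it does not separate the two compounds. Trifluoromethyl in place of hydrogen on an aromatic carbon, with the methoxy group kept, gives a number 10.6 percentage points higher from compound 2 to compound 4 (beyond the scatter), a modest step. Nothing shown here accounts for either step. The compounds shown leave open how an amine or an ethoxy group would read at this place. They also leave open whether hydroxy to methoxy would give a similar step with the (3,4-dichlorophenyl)amino group of compound 1 on the carbonyl carbon.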